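Swapping the azidomethyl of compound 1 for an enyne

The source may report more compounds than this note shows. Statements on the series, on what has been measured and on what is new or still open speak of the compounds shown alone.

Measured compounds:
compound 1, `[N-]=[N+]=NCc1cn([C@H]2C[C@H](O)[C@@H](CO)O2)c(=O)[nH]c1=O`: 124000 nM
compound 2, `Nc1ncnc2c1ncn2[C@@H]1O[C@H](/C=C/F)[C@H](O)[C@@H]1O`: > 200000 nM
compound 3, `CC1(C)C(CO)CC1Cn1nnc2c(Cl)nc(N)nc21`: > 200000 nM

Going by the values given here, in an ADME assay on L1210/0 cells (Mus musculus) for cytotoxicity, with a stated time of 48 h (a lower number here means a stronger inhibitor, a higher number a weaker inhibitor), compound 1 gives 124000 nM, and this is the only number among the values shown. For compound 2 the entry > 200000 nM is a limit of the assay, not a number. For compound 3 the entry > 200000 nM is likewise a limit. Among the compounds with values here, compound 1 is therefore the one compound with a measured figure, and it sits at the weak end of what this assay resolves; two of three entries sit at the limit of > 200000 nM in this assay, at which 2 of the 3 values shown sit.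

Compound 4, `C=CC#Cc1cn([C@H]2C[C@H](O)[C@@H](CO)O2)c(=O)[nH]c1=O`, has not yet been measured. It differs from compound 1 by a group of 4 heavy atoms (4 carbon; no ring) in place of a group of 4 heavy atoms (1 carbon, 3 nitrogen; no ring), on an aromatic carbon, two atoms from the ring nitrogen. Within the data shown here, no step between two measured compounds is given, so nothing here tells how such a change moves the number. The account expects the step from compound 1 to compound 4 to stay within the usual scatter, with a modest lean toward a lower number, a 1.6-fold lower number from compound 1 to compound 4 (0.19 log units; within the scatter). Compound 4 is thus estimated at 80000 nM, between 15000 nM and 200000 nM.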

Compound 4, half-maximal inhibitory concentration: > 200000 nM
Compound 4: no number, only a limit; the forecaster's own chance of this, stated with the estimate: 35%; middle value at least 2.5-fold (0.39 log units) away from the limit.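

Putting the enyne in place of the azidomethyl on this aromatic carbon gives an at least 1.6-fold higher number from compound 1 to compound 4 (0.20 log units; that floor lies within the scatter). This is the first step shown at this position, and it brings no lower number in this assay, although its floor does not separate the two compounds. What the result adds is one more compound at the edge of what the read-out resolves, so that the measured figure of compound 1 remains the only number in the set: the limit of > 200000 nM in this assay, at which 3 of the 4 values shown sit.

From the compounds shown here alone, how far compound 4 lies past its limit stays open, and with it the true size of the step. Also open, going by these compounds, is whether an amine, a carboxylic acid or a longer chain on this aromatic carbon would move the number in either direction beyond the scatter.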